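Moving a methoxy group around a phenyl ring: cytotoxicity unchanged?

The source may report more compounds than this note shows. Statements on the series, on what has been measured and on what is new or still open speak of the compounds shown alone.

This piece follows one change on a shared core and asks what it does to toxicity toward cells. Compound 1 `COc1cccc(-c2cc(C)cn3c(CSCCc4ccccc4)cnc23)c1` was measured in an ADME assay on HEL cells (Homo sapiens) for cytotoxicity, with a stated time of 3 days (on this read-out lower numbers stand for higher toxicity in this test and higher numbers for lower toxicity in this test), and for compound 1 the result is only a limit of the assay, > 50 ug/mL, not a number. Compound 2 `Cc1cc(-c2ccc(O)cc2)cn2c(CSCCc3ccccc3)cnc12` carries a hydroxyphenyl group in the same place. In this assay compound 2 also gives only a limit, > 50 ug/mL. So where compound 1 stands is known only as a boundary, and both values shown sit at that same boundary (the limit of > 50 ug/mL in this assay, at which 2 of the 2 values shown sit); no difference between the two can be read from them.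

Compound 3 `COc1ccc(-c2cc(C)cn3c(CSCCc4ccccc4)cnc23)cc1` is the compound not yet measured. It differs from compound 1 in one place (4-methoxyphenyl in place of 3-methoxyphenyl on an aromatic carbon). Among the measured compounds shown here, no measured step between two compounds is available, so the size of this change has to be guessed. With both known values sitting at the same limit, the step from compound 1 to compound 3 in this assay is expected to be none beyond the usual scatter, a number no higher from compound 1 to compound 3 (the limit leaves the size open). Compound 3 is therefore expected to give about 50 ug/mL, somewhere between 30 ug/mL and 100 ug/mL, most likely again reported only as a limit.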

Compound 3, half-maximal cytotoxic concentration: 19.6 ug/mL
Estimate against measurement, compound 3: 2.6-fold (0.41 log units) above, outside the stated range (below it).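

Swapping 3-methoxyphenyl for 4-methoxyphenyl gives an at least 2.5-fold lower number from compound 1 to compound 3 (0.40 log units; beyond the scatter) in this assay, so on this ring position the methoxy group's place on the phenyl ring does matter, and lower numbers here mean more toxicity to the cells. The two groups have the same atoms and the same counts of hydrogen-bond donors and acceptors, so the result is tied to placement on the phenyl ring alone, although these data do not explain how that placement acts. Among the compounds shown here, compound 3 also gives the first actual number in the set, 19.6 ug/mL, which shows that this series can reach a measurable level of toxicity within the range of the test.

As far as these compounds go, how large the step really is stays open, and it can only be stated as a minimum because most of the values are still limits rather than numbers: the limit of > 50 ug/mL in this assay, at which 2 of the 3 values shown sit. Also open, from the compounds shown here alone, is whether a different group at the same spot on the phenyl ring, such as an amine or a carboxylic acid in place of the methoxy group, would stay at the limit or give a number like that of compound 3.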